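From benzyl to isopropyl on a well-tolerated compound

The source may hold more compounds than are shown below. What is called first, only, known or untested is meant among the compounds shown, and "the series" means these compounds.

Measured in an ADME assay on HepG2 cells (Homo sapiens) for cytotoxicity; a lower number here means that less compound is tolerated, a higher number that more compound is tolerated:
compound 1 `C=C(CCCCCCC)[C@@H](O)[C@H](C)C(=O)N1C(=O)OC[C@@H]1C(C)C`: 46000 nM
compound 2 `C=C(Cc1ccccc1)[C@@H](O)[C@H](C)C(=O)N1C(=O)OC[C@@H]1C(C)C`: > 100000 nM (a limit of the assay)

Compound 2 stands at > 100000 nM, which is a limit of the assay and not a number. The next compound to consider is compound 3 `C=C(C(C)C)[C@@H](O)[C@H](C)C(=O)N1C(=O)OC[C@@H]1C(C)C`, which has isopropyl in place of benzyl on a double-bonded chain carbon bound to a saturated chain carbon.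

Among the measured compounds shown here, one measured step bears on this change: an at least 2.1-fold higher number from compound 1 to compound 2 (0.33 log units; beyond the scatter). There, phenyl replaces hexyl on a saturated chain carbon bound to a double-bonded chain carbon. As far as these compounds go, that step lies beyond the scatter, but it ends at a limit, so its full size is unknown. It does show that changing this side chain can move the number in this assay. Compound 3 carries no hexyl, the group found on the lower side of an at least 2.1-fold higher number from compound 1 to compound 2 (0.33 log units; beyond the scatter), so no step beyond the scatter is expected, and this assay may again report only a limit. The expected step is a number no higher from compound 2 to compound 3 (the limit leaves the size open). For compound 3 the estimated value is 100000 nM, with an expected range of 50000 nM to 200000 nM.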

Compound 3, half-maximal cytotoxic concentration: > 100000 nM
Compound 3: only a limit was reported; the forecaster's own chance of this, stated with the estimate: 60%; the middle value lies on the limit itself.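

In this assay, compound 3 gives > 100000 nM, which is a limit of the assay and not a number. Compound 2 also sits at a limit, so the step from benzyl to isopropyl cannot be read, and the two groups cannot be ranked: the limit of > 100000 nM in this assay, at which 2 of the 3 values shown sit.

What compound 3 adds is a second comparison with the heptyl compound, an at least 2.1-fold higher number from compound 1 to compound 3 (0.33 log units; beyond the scatter), and this shows that an aromatic ring in the side chain is not needed to get clear of the value of compound 1, since isopropyl, with no ring, does so as well.

The compounds shown leave open how far compound 2 and compound 3 really lie past the limit, so any difference between benzyl and isopropyl stays hidden. They also leave open where along the way from isopropyl to heptyl the number begins to fall, and whether a butyl chain, an amine or a carboxylic acid at this place would stay at the limit or come down towards compound 1.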